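The compounds below may be only part of what the source reports. "The series", "measured", "known", "first", "only" and "open" are said of these compounds alone.

Compound 1, `CCOC(=O)c1c(-c2cccc(-c3ccccc3)c2)[nH]c2cc(OC(C)C)ccc2c1=O`: in an ADME assay on Raji cells (Homo sapiens) for cytotoxicity, read by luminescence, with a stated time of 72 h (a lower number here means that less compound is needed, a higher number that more compound is needed for the effect), compound 1 is reported only as a limit of the assay, > 21500 nM.
Compound 2, `CCOC(=O)c1c(-c2cccc(OC)c2)[nH]c2cc(OC(C)C)ccc2c1=O`: in this assay compound 2 is likewise reported only as a limit, > 21500 nM.
Compound 3, `CCOC(=O)c1c(-c2cccc(-c3ccccc3)c2)[nH]c2cc(OC)c(OC)cc2c1=O`: in this assay compound 3 is also reported only as a limit, > 21500 nM.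

Compound 1 and compound 2 differ in one place, by methoxy in place of phenyl on an aromatic carbon. The step they make, a step that the two limits leave unreadable from compound 1 to compound 2, cannot be read, since each of the two values is a limit rather than a number. Compound 3 shares the same ethyl ester and ketone with compound 1 but carries a different core; the difference between the two cores is not broken down here. Compound 4, `CCOC(=O)c1c(-c2cccc(OC)c2)[nH]c2cc(OC)c(OC)cc2c1=O`, stands to compound 3 as compound 2 stands to compound 1: it is made by methoxy in place of phenyl on an aromatic carbon, and as the two changes sit in the same surroundings they count as the same change.

The expectation for compound 4 rests on the limit of > 21500 nM in this assay, at which 3 of the 3 values shown sit: with every measured value sitting at the limit, the step from compound 3 to compound 4 is expected to be a step that the limit leaves unreadable from compound 3 to compound 4, beside the unreadable earlier one. Compound 4 is therefore estimated at 30000 nM in this assay, with a likely span from 15000 nM to 100000 nM, most probably reported as a limit again.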

Compound 4, half-maximal effective concentration: > 21500 nM
Compound 4 was reported as a limit; the forecaster's own chance of this, stated with the estimate: 85%; the middle value is on the limit's open side.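

No new step can be read: in this assay compound 3 and compound 4 are both reported only as limits, not as numbers, so the change between them has no readable size. The compounds shown leave open where any of the four actual values lies, and whether methoxy in place of phenyl on an aromatic carbon shifts them at all.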